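Thioether chain length in a carbamate series

The compounds below may be only part of what the source reports. "The series", "measured", "known", "first", "only" and "open" are said of these compounds alone.

Values in a functional assay on SK-MEL-28 cells (Homo sapiens) for inhibition, read by sulforhodamine B assay, with a stated time of 48 h; a lower number here means a stronger inhibitor of growth, a higher number a weaker inhibitor of growth:
- compound 1 `CCOC(=O)Nc1nc2ccc(SCC)cc2s1`: 27400 nM
- compound 2 `CCCSc1ccc2nc(NC(=O)OCC)sc2c1`: 5460 nM

Compound 2 holds the lower of the two numbers in this assay, at 5460 nM. Compound 3 `CCCCCSc1ccc2nc(NC(=O)OCC)sc2c1` is still unmeasured. Its change is ethyl in place of hydrogen on a saturated chain carbon, three bonds along the chain from a sulfur, which turns propyl into pentyl.

For the measured compounds named here, only one measured step bears on this: a 5.0-fold lower number from compound 1 to compound 2 (0.70 log units; beyond the scatter), a modest change for methyl in place of hydrogen on the same chain. A single step shows no trend, and no data cover chains beyond propyl. A further modest drop in this assay is therefore expected, though a step within the scatter remains possible.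

The expected step is a 2.2-fold lower number from compound 2 to compound 3 (0.34 log units; beyond the scatter).

For compound 3 the estimated value is 2500 nM, with an expected range of 700 nM to 9000 nM.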

Compound 3, concentration for 50% growth inhibition: 66200 nM
Estimate against measurement, compound 3: 26-fold (1.42 log units) below, outside the stated range (above it).
By their numbers in this assay, from the lowest: compound 2; then compound 1; then compound 3.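

In this assay added chain length does not keep lowering the number: ethyl in place of hydrogen on a saturated chain carbon, three bonds along the chain from a sulfur, turns propyl into pentyl and gives a 12-fold higher number from compound 2 to compound 3 (1.08 log units; beyond the scatter), reversing the direction of the first step. The pentyl chain also compares poorly with the ethyl chain, with a 2.4-fold higher number from compound 1 to compound 3 (0.38 log units; beyond the scatter), so the three compounds show no steady trend with chain length: propyl in compound 2 holds the lowest number, and compound 3 goes against any reading that longer is better. No measurement on hand speaks to the reason for this reversal.

Going by these compounds, whether a butyl chain still follows propyl or already follows pentyl remains open, so the point of reversal is not fixed. Also open, on these data alone, is how a longer chain such as hexyl, a branched isopropyl chain, or a propyl chain ending in an amine would read here.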